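This account rests on a few compounds, and the source may have more. Where it says the series, first, only, none or still open, it means among the compounds named here.

Working notes on the series. Among the compounds with values here, in a functional assay on HT-29 cells (Homo sapiens) for antiproliferative activity, read by sulforhodamine B assay, with a stated time of 48 h (a lower number here means a stronger inhibitor, a higher number a weaker inhibitor), compound 3 (`O=C1NCCN1c1ccc(S(=O)(=O)Nc2cccc(Br)c2)cc1`) gives 77 nM, the lowest number so far. Compound 1 (`Cc1ccc(NS(=O)(=O)c2ccc(N3CCNC3=O)cc2)cc1C`) gives 230 nM in this assay. Within the data shown here, the one measured step is a 3.0-fold lower number from compound 1 to compound 3 (0.48 log units; beyond the scatter), with 3-bromophenyl in place of 3,4-dimethylphenyl on a sulfonamide nitrogen. Compound 2 (`CCCCCCCc1ccc(NS(=O)(=O)c2ccc(N3CCNC3=O)cc2)cc1`) is recorded only as a limit, > 1000 nM. This entry (the limit of > 1000 nM in this assay, at which 1 of the 3 values shown sits) gives no step size.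

The next entry is compound 4 (`O=C1NCCN1c1ccc(S(=O)(=O)Nc2ccc(Cl)cc2)cc1`), with 4-chlorophenyl in place of 3-bromophenyl on a sulfonamide nitrogen. Among the measured compounds shown here, no measured compound carries 4-chlorophenyl, and no measured step starts from compound 3. The nearest guide is therefore the modest step of a 3.0-fold lower number from compound 1 to compound 3 (0.48 log units; beyond the scatter), which involves a different pair of groups and bears on this change only loosely. With compound 3 at 77 nM as the lowest number, the expectation in this assay is a move towards a higher number, no larger than about that modest step and possibly within the scatter. The expected change is a 1.9-fold higher number from compound 3 to compound 4 (0.29 log units; within the scatter). For compound 4 the estimated value is 150 nM, with an expected range of 45 nM to 500 nM.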

Compound 4, half-maximal inhibitory concentration: 220 nM
For compound 4 the middle estimate is 1.5-fold (0.17 log units) below the measured one; low and high end bracket the measured number.
By their numbers in this assay, from the lowest: compound 3; then compounds 4 and 1 (each within the scatter of the next). At a limit, above all of these: compound 2.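

On a sulfonamide nitrogen, the aryl group clearly matters in this assay: a 2.9-fold higher number from compound 3 to compound 4 (0.46 log units; beyond the scatter), so replacing 3-bromophenyl with 4-chlorophenyl does not preserve the reading of compound 3. The two aryl groups on compound 1 and compound 4 are not separated, since the step is a 1.0-fold lower number from compound 1 to compound 4 (0.02 log units; within the scatter), which leaves 3,4-dimethylphenyl and 4-chlorophenyl level in this assay and compound 3 alone beyond the scatter from either. Chloro in place of heptyl on an aromatic carbon gives an at least 4.5-fold lower number from compound 2 to compound 4 (0.65 log units; beyond the scatter), but this step is only a bound, resting on the value of compound 2, which is a limit and not a number: the limit of > 1000 nM in this assay, at which 1 of the 4 values shown sits.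

The step from bromo to chloro also changes the name of the substituted position, so the compounds shown do not separate the halogen from where it stands on the phenyl ring. From the compounds shown here alone, how 3-chlorophenyl, 4-bromophenyl, a phenyl carrying an amine or a carboxylic acid, or a chain shorter than heptyl would read in this assay remains open.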